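A few compounds are considered here, and "the series" means these few. Any claim that something is new, unique, unknown or untested is made for them only; others in the source may bear on it.

Two compounds of the series have numbers in a functional assay on NCI-H23 cells (Homo sapiens) for inhibition, read by sulforhodamine B assay, with a stated time of 48 h, tested at 10 uM (on this read-out lower numbers stand for less inhibition of growth and higher numbers for more inhibition of growth at the one concentration tested), so far. Compound 1 `CC(=O)c1cccc(Nc2ccnc(SCC(=O)c3ccc(-c4ccccc4)cc3)n2)c1` gives 18% there. For the measured compounds named here, compound 2 `CCOC(=O)c1ccc(Nc2ccnc(SCC(=O)c3ccc([N+](=O)[O-])cc3)n2)cc1` gives 13% there, a number lying within the usual scatter of the one for compound 1, so the two stand together and neither is set apart. Compound 3 `CCOC(=O)c1ccc(Nc2ccnc(SCC(=O)c3ccc(C#N)cc3)n2)cc1` is not yet measured; it differs from compound 2 in one place: cyano in place of nitro on an aromatic carbon. Going by the values given here, no step between measured compounds covers this change, and both measured numbers are low. For compound 3 the expected step is no change at the digits printed from compound 2 to compound 3 (within the scatter), none beyond the scatter. Compound 3 is estimated at 13%, within 3% to 25%.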

Compound 3, percent growth inhibition at one concentration: 20%
For compound 3 the middle estimate is 7 percentage points below the measured one; the measured number falls inside the stated range.
By their numbers in this assay, from the lowest: compounds 2, 1 and 3 (each within the scatter of the next).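

In this assay, for the compounds shown here, the change from 4-nitrophenyl to 4-cyanophenyl reads as a number 7 percentage points higher from compound 2 to compound 3 (within the scatter), the first step that can be read at this position. The position para to a large group therefore takes either nitro or cyano with no change that stands out from the scatter, and the number stays low with both groups. Nothing at hand speaks to a cause for this step.

Going by these compounds, whether an amine or a carboxylic acid on this carbon would give a step beyond the scatter remains open. Also open, on these data alone, is whether cyano in place of nitro reads the same way with a group other than the ethyl ester elsewhere on the core.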